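Carboxymethoxy in place of carboxy on the acid-bearing ring

The source may hold more compounds than are shown below. What is called first, only, known or untested is meant among the compounds shown, and "the series" means these compounds.

Compound 1 `O=C(N[C@H]1CC[C@H](C(=O)O)CC1)[C@H](C1CCCCC1)n1c(-c2ccc(Cl)nc2)nc2cc(F)c(F)cc21` is the reference point of this set. In a functional assay for agonist activity at Bile acid receptor (Homo sapiens), read by a luciferase reporter (on this read-out higher numbers stand for larger maximal responses and lower numbers for smaller maximal responses), compound 1 gives 18%. Compound 2 `COc1ccc(-c2nc3cc(F)c(F)cc3n2[C@H](C(=O)N[C@H]2CC[C@H](C(=O)O)CC2)C2CCCCC2)c(Cl)n1` gives 21% in this assay, and compound 3 `O=C(O)CCc1ccc(NC(=O)C(C2CCCCC2)n2c(-c3ccc(Cl)cc3)nc3cc(F)c(F)cc32)cc1` gives 18%. Compound 1 shares its number with compound 3 at the digits shown, and the gap to compound 2, a number 3 percentage points higher from compound 1 to compound 2 (within the scatter), lies within the scatter; all three numbers are therefore indistinguishable on this read-out.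

Compound 4 `O=C(O)CO[C@H]1CC[C@H](NC(=O)[C@H](C2CCCCC2)n2c(-c3ccc(Cl)nc3)nc3cc(F)c(F)cc32)CC1` is not yet measured. It differs from compound 1 by carboxymethoxy in place of carboxy on a saturated ring carbon. Within the data shown here, the only step measured so far, a number 3 percentage points higher from compound 1 to compound 2 (within the scatter), changes a group on an aromatic carbon of the shared core and says nothing about the acid-bearing end of the molecule. Among the measured compounds shown here, compounds 1 and 3 carry the acid on different frameworks and give the same number, which suggests that the acid-bearing part tolerates variation without moving the maximal response, but no single-point step between them exists, so this is only what the two values show.

On that basis the step to compound 4 is expected to be small: no change at the digits printed from compound 1 to compound 4 (within the scatter), no change beyond the scatter. Compound 4 is estimated at 18%, with a range from 8% to 30%.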

Compound 4, largest response reached (reported as efficacy), in percent of the reference or control that the assay uses: 26%
For compound 4 the middle estimate is 8 percentage points below the measured one, within the range that was stated.
By their numbers in this assay, from the lowest: compounds 1, 3, 2 and 4 (each within the scatter of the next).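

In this assay, among these compounds, the saturated ring carbon, three ring bonds from the ring atom that bears a large group, accepts carboxymethoxy in place of carboxy with a number 8 percentage points higher from compound 1 to compound 4 (within the scatter) as the first single-place reading at the acid-bearing end of the series. The extra heavy atoms and the added hydrogen-bond acceptor of carboxymethoxy thus come with no change beyond the scatter, so the acid need not sit directly on the saturated ring for the maximal response to stay at the level of compound 1. No measured data here bear on why this change is tolerated.

As far as these compounds go, it remains open whether a longer chain such as carboxypropoxy, or a replacement of the acid by a primary amide or a tetrazole at this ring carbon, would move the maximal response beyond the scatter. Also open, from the compounds shown here alone, is whether carboxymethoxy gives a similar step when combined with the aromatic group carried by compound 2, since the two changes are seen here only separately on the core of compound 1.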